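The compounds below may be only part of what the source reports. "The series", "measured", "known", "first", "only" and "open" are said of these compounds alone.

Measured in a functional assay on DU-145 cells (Homo sapiens) for inhibition, read by trypan blue exclusion, with a stated time of 96 h; a higher number here means a weaker inhibitor of growth, a lower number a stronger inhibitor of growth:
compound 1 `Cc1ccc(S/C(=C/c2c[nH]c3ccccc23)C(=O)c2ccc(Br)cc2)cc1`: 10000 nM
compound 2 `CCOc1cc(/C=C(\C(=O)c2ccc(Cl)cc2)S(=O)(=O)Cc2ccc(Cl)cc2)ccc1O`: 10000 nM
compound 3 `COc1cc(OC)c(/C=C(/C(=O)c2ccc(Cl)cc2)S(=O)(=O)Cc2ccccc2Cl)c(OC)c1`: > 100000 nM

Compound 1 stands level with compound 2, and the two values lie within the scatter of each other. For compound 3, > 100000 nM is a limit of the assay and not a number.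

The next compound to be tested is compound 4 `CSc1ccc(/C=C(/Sc2ccc(C)cc2)C(=O)c2ccc(Br)cc2)cc1`. It carries 4-(methylsulfanyl)phenyl in place of 1H-indol-3-yl on a double-bonded chain carbon bound to a double-bonded chain carbon. The rest of the core of compound 1 is retained.

For the measured compounds named here, no two measured compounds differ in only one place, so no measured step shows what this replacement does in this assay. The closest guide is compound 1 itself at 10000 nM. With no direct evidence for either direction, the working expectation is no change beyond the scatter, although a real shift either way remains possible. The estimated step of no change at the digits printed from compound 1 to compound 4 (within the scatter) is expected to be small. For compound 4 the estimated growth-inhibition value is 10000 nM, with an expected range of 2000 nM to 50000 nM.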

Compound 4, concentration for 50% growth inhibition: 50000 nM
Beside the measured number, compound 4's estimate is 5.0-fold (0.70 log units) below it, and the stated range covers the measured number.
By their numbers in this assay, from the lowest: compounds 1 and 2 (each within the scatter of the next); then compound 4. At a limit, above all of these: compound 3.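

In this assay, for the compounds shown here, this is the first step that can be read, and it shows that the position on a double-bonded chain carbon bound to a double-bonded chain carbon is not indifferent to its group: 4-(methylsulfanyl)phenyl in place of 1H-indol-3-yl gives a 5.0-fold higher number from compound 1 to compound 4 (0.70 log units; beyond the scatter), a modest loss of growth inhibition beyond the scatter. The exchange removes the five-membered aromatic ring and the hydrogen-bond donor and brings in sulfur and a hydrogen-bond acceptor, so this single step cannot separate these changes from one another. Nothing available bears on the cause of the rise.

Steps from compound 2 or compound 3 to the other compounds cannot be read, as each differs from them in more than one place, so the role of the other parts of the core remains untested. Also open, from the compounds shown here alone, is whether a plain phenyl, a 4-aminophenyl or a 4-hydroxyphenyl at this position would match compound 1 or fall further away, which would show whether the indole ring itself or its amine hydrogen matters here.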